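The compounds below may be only part of what the source reports. "The series", "measured", "known", "first", "only" and "open" are said of these compounds alone.

Working notes on the series. Compound 1 `CCNC(=O)c1nc(-c2cc(OC)c(OC)c(OC)c2)n(-c2ccc(OC)cc2)n1` in a functional assay on the whole organism for inhibition, with Rattus norvegicus as the target, read by paw edema, with stated times of 30 min and 3 h, at a dose of 0.28 mmol/kg by the oral route (a higher number here means more inhibition at the dose given (going by the name of the read-out), a lower number less inhibition), gives 69%. Within the data shown here, compound 2 `COc1ccc(NC(=O)c2nc(-c3cc(OC)c(OC)c(OC)c3)n(-c3ccc(OC)cc3)n2)cc1` in this assay gives 67%; of the two numbers measured so far it is the one not matched by another below it, but the step of a number 2 percentage points lower from compound 1 to compound 2 (within the scatter) lies within the scatter, so the two compounds are not separated on this read-out.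

Compound 3 `COc1ccc(-n2nc(C(=O)Nc3ccccc3C)nc2-c2cc(OC)c(OC)c(OC)c2)cc1` is not yet measured in this assay. It differs from compound 2 by 2-methylphenyl in place of 4-methoxyphenyl on an amide-type nitrogen. Among the measured compounds shown here, the only measured step that touches the same position is the one that also alters the group on the amide-type nitrogen, a number 2 percentage points lower from compound 1 to compound 2 (within the scatter), and it stayed within the scatter. On that single precedent a step beyond the scatter is not expected; the estimated step is a number 2 percentage points lower from compound 2 to compound 3 (within the scatter). Compound 3 is therefore expected to give about 65%, with a range of 50% to 78%.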

Compound 3, a percentage reported as inhibition, in the whole organism at one dose (the size of the read-out at that dose, not a potency): 50%
Compound 3: middle estimate off by 15 percentage points, on the high side; the range from low to high includes it.
By their numbers in this assay, from the lowest: compound 3; then compounds 2 and 1 (each within the scatter of the next).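

The group on the amide-type nitrogen does matter in this assay: the step is a number 17 percentage points lower from compound 2 to compound 3 (beyond the scatter), and it is a number 19 percentage points lower from compound 1 to compound 3 (beyond the scatter), whereas ethyl and 4-methoxyphenyl at this place could not be separated on this read-out. An aromatic ring on this nitrogen therefore does not settle the number by itself, since 4-methoxyphenyl and 2-methylphenyl each carry one six-membered aromatic ring of carbon only and still part beyond the scatter. Nothing available here bears on why these two groups differ.

The compounds shown do not tell whether the lower number goes with the methyl group or with where it sits on the ring, a question that 4-methylphenyl, 2-methoxyphenyl or plain phenyl on the same nitrogen would address. As far as these compounds go, how a longer alkyl chain or a chain ending in an amine would behave at this place also stays open.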